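This account rests on a few compounds, and the source may have more. Where it says the series, first, only, none or still open, it means among the compounds named here.

Measured compounds in this series:

- compound 1 `CNC(=O)c1cc(C(=O)NC2CCC2)cn(Cc2cccc(NC)c2)c1=O`: >= 155 ug/mL in a physicochemical assay for solubility; a lower number here means a less soluble compound, a higher number a more soluble compound
- compound 2 `CNC(=O)c1cc(C(=O)NCCC2CCOCC2)cn(Cc2ccccc2)c1=O`: >= 127 ug/mL
- compound 3 `CNC(=O)c1cc(C(=O)NC2CC2)cn(CC2CCCOC2)c1=O`: >= 131 ug/mL

Every one of the three values is a limit of this assay and not a number. The value of compound 2 is such a limit (the limit of >= 127 ug/mL in this assay, at which 1 of the 3 values shown sits). The value of compound 3 is likewise a limit (the limit of >= 131 ug/mL in this assay, at which 1 of the 3 values shown sits). The value of compound 1 is also a limit (the limit of >= 155 ug/mL in this assay, at which 1 of the 3 values shown sits). Compound 2 therefore stands at a limit, and the two other values shown are limits too, so no ordering among the three can be read from this assay.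

The next compound in the series is compound 4 `CNC(=O)c1cc(C(=O)NCCO)cn(Cc2ccccc2)c1=O`. Its difference from compound 2, counted from the two structures, is hydroxy in place of oxan-4-yl on a saturated chain carbon, two bonds along the chain from an amide-type nitrogen. Among the measured compounds shown here, no step between two measured compounds is available for this assay, and nothing among the three values shown says anything about the direction of a change in this assay; all three sit at a limit. The expectation is therefore that the step that the limit leaves unreadable from compound 2 to compound 4 is none beyond the scatter, with compound 4 most likely again reported only as a limit. Compound 4 is estimated at 180 ug/mL, within a range from 100 ug/mL to 400 ug/mL.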

Compound 4, solubility: >= 140 ug/mL
Compound 4: only a limit was reported; the forecaster's own chance of this, stated with the estimate: 75%; the middle value is on the limit's open side.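

In this assay, among the compounds shown here, compound 2 and compound 4 are both reported only as limits, so no step between them can be read. The compounds shown leave open how all four rank in this read-out and whether hydroxy in place of oxan-4-yl changes it at all.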